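The compounds below may be only part of what the source reports. "The series", "measured", "known", "first", "only" and "open" are said of these compounds alone.

Compound 2 `COc1cc2nc(N3CCN(C(=O)/C=C/c4ccc(N=C=S)cc4)CC3)nc(N)c2cc1OC` gives 102 nM in an assay on cell membranes for displacement of a labelled ligand from Adrenergic receptor alpha-1 (Rattus norvegicus), tested at 100 nM (on this read-out higher numbers stand for weaker inhibition and lower numbers for stronger inhibition), the highest of the two numbers recorded so far; the nearest is compound 1 `COc1ccc(/C=C/C(=O)N2CCN(c3nc(N)c4cc(OC)c(OC)cc4n3)CC2)cc1`, which gives 3.39 nM in this assay. Compound 3 `COC(=O)/C=C/C(=O)Nc1ccc(/C=C/C(=O)N2CCN(c3nc(N)c4cc(OC)c(OC)cc4n3)CC2)cc1` is not yet measured. It differs from compound 2 in that (a group of 9 heavy atoms (5 carbon, 1 nitrogen, 3 oxygen; no ring) in place of a group of 3 heavy atoms (1 carbon, 1 nitrogen, 1 sulfur; no ring), on an aromatic carbon). Within the data shown here, only one measured step touches the same place on the ring: a 30-fold higher number from compound 1 to compound 2 (1.48 log units; beyond the scatter). That step shows that the group on this aromatic carbon can shift the number strongly, but the group entering compound 3 resembles neither the isothiocyanate nor the methoxy group, so the direction is uncertain. Since compound 1 carries an oxygen-bearing group at the same place and gives 3.39 nM, a number for compound 3 lying between the two measured values seems most plausible. For compound 3 the estimate is a 4.1-fold lower number from compound 2 to compound 3 (0.61 log units; beyond the scatter), giving 25 nM with a range from 5 nM to 120 nM.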

Compound 3, half-maximal inhibitory concentration: 29.5 nM
Compound 3: middle estimate off by 1.2-fold (0.07 log units), on the low side, and the stated range covers the measured number.
By their numbers in this assay, from the lowest: compound 1; then compound 3; then compound 2.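

Replacing the sulfur-bearing group with the much larger ((2-(methoxycarbonyl)ethenyl)carbonyl)amino group gives a 3.5-fold lower number from compound 2 to compound 3 (0.54 log units; beyond the scatter) in this assay, so the number at this aromatic carbon does not simply rise with the size of the group, and compound 3 goes against any such trend. The large group still does not match methoxy, with an 8.7-fold higher number from compound 1 to compound 3 (0.94 log units; beyond the scatter) in this assay, and compound 1 keeps the lowest number of the three. No measurement at hand accounts for either shift.

The compounds shown leave open which part of the entering group sets its number: the amide hydrogen, the ethenyl chain or the methyl ester. A plain amine or a carboxylic acid at this aromatic carbon would help to separate these parts.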